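Nitro for hydroxy on the methoxyphenyl ketone

A few compounds are considered here, and "the series" means these few. Any claim that something is new, unique, unknown or untested is made for them only; others in the source may bear on it.

- compound 1 (`COc1cc(OC)c2sc(-c3ccc(N/C=C\C(=O)c4ccc(OC)c([N+](=O)[O-])c4)c(C)c3)nc2c1`) gives 13900 nM
- compound 2 (`COc1cc(OC)c2sc(-c3ccc(N/C=C\C(=O)c4ccc(OC)c(O)c4)cc3)nc2c1`) gives 11600 nM

In a functional assay on MIA PaCa-2 cells (Homo sapiens) for antiproliferative activity, read by sulforhodamine B assay, with a stated time of 48 h (a higher number here means a weaker inhibitor, a lower number a stronger inhibitor), compound 2 gives 11600 nM and stands within the scatter of compound 1. Compound 3 (`COc1cc(OC)c2sc(-c3ccc(N/C=C\C(=O)c4ccc(OC)c([N+](=O)[O-])c4)cc3)nc2c1`) has nitro in place of hydroxy on an aromatic carbon, ortho to a methoxy group (nitro in place of hydroxy on an aromatic carbon). Among the measured compounds shown here, no measured pair isolates this change. Compound 1 also carries 4-methoxy-3-nitrophenyl and gives (13900 nM), although it differs elsewhere from compound 2 too. No step beyond the scatter is expected, and the estimated step is (a 1.1-fold higher number from compound 2 to compound 3 (0.03 log units; within the scatter)). Compound 3 is estimated at 12500 nM (5000 nM to 30000 nM).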

Compound 3, half-maximal inhibitory concentration: 2900 nM
Compound 3: middle estimate off by 4.3-fold (0.63 log units), on the high side; the measured number lies below the stated range.
By their numbers in this assay, from the lowest: compound 3; then compounds 2 and 1 (each within the scatter of the next).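

In this assay, the nitro group at this aromatic carbon is a real gain over hydroxy, with nitro in place of hydroxy giving a 4.0-fold lower number from compound 2 to compound 3 (0.60 log units; beyond the scatter). The close match of compound 1 and compound 2 had concealed two separate steps, and the second, hydrogen in place of methyl on an aromatic carbon, gives a 4.8-fold lower number from compound 1 to compound 3 (0.68 log units; beyond the scatter). Nothing available here explains either step.

On these data alone, whether the gain is particular to nitro remains open, and a nitrile, an amine or a carboxylic acid on this carbon would test it. Also open, as far as these compounds go, is whether the methyl step holds with hydroxy in place of nitro.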